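A few compounds are considered here, and "the series" means these few. Any claim that something is new, unique, unknown or untested is made for them only; others in the source may bear on it.

Among the compounds with values here, in an assay on cells for displacement of a labelled ligand from 5-hydroxytryptamine receptor 7 (Homo sapiens), read by scintillation counting, with a stated time of 30 min (a higher number here means a weaker inhibitor, a lower number a stronger inhibitor), compound 3 `O=C(CCN1CCN(c2ccc(Cl)cc2)CC1)N1CCN(c2cccc(Cl)c2)CC1` gives 2370 nM, the second highest of the three numbers measured so far. Its nearest neighbour is compound 2 `O=C(CCN1CCN(c2cccc(Cl)c2)CC1)N1CCN(c2cccc(Cl)c2)CC1`, which gives 2760 nM; the change between them is a 1.2-fold lower number from compound 2 to compound 3 (0.07 log units; within the scatter). Furthest away is compound 1 `CCOc1ccccc1N1CCN(CCC(=O)N2CCN(c3ccccc3)CC2)CC1`, which gives 80.3 nM. Compound 4 `CCOc1ccccc1N1CCN(CCC(=O)N2CCN(c3cccc(Cl)c3)CC2)CC1` differs from compound 3 by 2-ethoxyphenyl in place of 4-chlorophenyl on an amine nitrogen in a ring. Within the data shown here, no measured step covers this exact change, and the one measured step lay within the scatter. Among the measured compounds shown here, compound 1, the only compound carrying a 2-ethoxyphenyl group, shows a far lower number than compound 2 and compound 3, though it differs from them in two places. A sizeable step toward a lower number is therefore expected, a 16-fold lower number from compound 3 to compound 4 (1.20 log units; beyond the scatter). The estimate for compound 4 is 150 nM, within a range from 40 nM to 600 nM.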

Compound 4, inhibition constant: 119 nM
For compound 4 the middle estimate is 1.3-fold (0.10 log units) above the measured one; low and high end bracket the measured number.
By their numbers in this assay, from the lowest: compounds 1 and 4 (each within the scatter of the next); then compounds 3 and 2 (each within the scatter of the next).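

Within the data shown here, putting 2-ethoxyphenyl on the amine nitrogen in the ring is now seen as a single change in this assay: there is a 20-fold lower number from compound 3 to compound 4 (1.30 log units; beyond the scatter) and a 23-fold lower number from compound 2 to compound 4 (1.37 log units; beyond the scatter), so the large effect no longer rests on compounds differing in two places. Chloro in place of hydrogen on an aromatic carbon stays within the scatter, with a 1.5-fold higher number from compound 1 to compound 4 (0.17 log units; within the scatter). No measurement shown here explains the large step.

Going by these compounds, what a 2-methoxyphenyl or 4-ethoxyphenyl group would give on that nitrogen stays open. So does the effect of a longer chain joining the two halves of the molecule.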